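The source may report more compounds than this note shows. Statements on the series, on what has been measured and on what is new or still open speak of the compounds shown alone.

Compound 3 `CC(C)=CC[C@@H](OC(=O)c1ccco1)C1=CC(=O)c2c(O)ccc(O)c2C1=O` is one of three closely related esters that have been tested in a functional assay on HeLa cells (Homo sapiens) for cytotoxicity, read by MTT assay; on this read-out lower numbers stand for stronger inhibition and higher numbers for weaker inhibition. In this assay compound 3 gives 80300 nM, compound 1 `CC(C)=CC[C@@H](OC(=O)CC(C)(O)c1ccccc1)C1=CC(=O)c2c(O)ccc(O)c2C1=O` gives 85700 nM, and compound 2 `CCCC(O)CC(=O)O[C@H](CC=C(C)C)C1=CC(=O)c2c(O)ccc(O)c2C1=O` gives 59300 nM; the three numbers lie within the usual scatter of one another, so none of them stands apart. The step of a 1.1-fold lower number from compound 1 to compound 3 (0.03 log units; within the scatter) and the step of a 1.4-fold higher number from compound 2 to compound 3 (0.13 log units; within the scatter) were both small, as was a 1.4-fold lower number from compound 1 to compound 2 (0.16 log units; within the scatter). Compound 4 `CCCC(CC(=O)O[C@H](CC=C(C)C)C1=CC(=O)c2c(O)ccc(O)c2C1=O)OC(C)=O` has not yet been measured. It differs from compound 3 by 2-acetoxypentyl in place of furan-2-yl on a carbonyl carbon. The measured step that bears most on this change is the reverse of a 1.4-fold higher number from compound 2 to compound 3 (0.13 log units; within the scatter), since compound 2 carries a 2-hydroxypentyl on the same carbonyl carbon and compound 4 a 2-acetoxypentyl; that step stayed within the scatter, as did every other change at this position. Compound 4 is therefore expected to give a number in this assay close to that of compound 3, with a 1.2-fold lower number from compound 3 to compound 4 (0.09 log units; within the scatter) no larger than the scatter, estimated at 65000 nM with a range from 30000 nM to 140000 nM.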

Compound 4, half-maximal inhibitory concentration: 51200 nM
Compound 4: the middle estimate sits 1.3-fold (0.10 log units) above what was measured; low and high end bracket the measured number.
By their numbers in this assay, from the lowest: compounds 4, 2, 3 and 1 (each within the scatter of the next).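

Acetyl in place of hydrogen on the oxygen of the side chain gives a 1.2-fold lower number from compound 2 to compound 4 (0.06 log units; within the scatter) in this assay and so shows that, in this pair, acylating that hydroxyl leaves the number within the scatter. At the carbonyl carbon, the open 2-acetoxypentyl chain, which has no ring, in place of furan-2-yl gives a 1.6-fold lower number from compound 3 to compound 4 (0.20 log units; within the scatter) and the 1-acetoxybutyl change gives a 1.7-fold lower number from compound 1 to compound 4 (0.22 log units; within the scatter) so this position has now taken an acylated chain as well as the earlier groups without any step leaving the scatter. No measurement shown here explains why these steps are so small.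

On these data alone, whether an amine or a carboxylic acid on this chain would move the number beyond the scatter remains open. The same holds for a much longer chain and for any change to the shared core.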